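From 3-amino-4-bromophenyl to 2-amino-4-chlorophenyl

This account rests on a few compounds, and the source may have more. Where it says the series, first, only, none or still open, it means among the compounds named here.

- compound 1 `COc1cc(OC)c(/C=C/S(=O)(=O)Cc2ccc(F)c(N)c2)c(OC)c1`: 2500 nM
- compound 2 `COc1ccc(CS(=O)(=O)/C=C/c2c(OC)cc(OC)cc2OC)c(N)c1`: 25 nM
- compound 3 `COc1cc(OC)c(/C=C/S(=O)(=O)Cc2ccc(Br)c(N)c2)c(OC)c1`: 750 nM

In a functional assay on K562 cells (Homo sapiens) for cytotoxicity, read by trypan blue exclusion, with a stated time of 96 h (on this read-out higher numbers stand for weaker inhibition and lower numbers for stronger inhibition), compound 3 holds the middle place of the three, at 750 nM. The next compound, compound 4 `COc1cc(OC)c(/C=C/S(=O)(=O)Cc2ccc(Cl)cc2N)c(OC)c1`, changes one group on a saturated chain carbon bound to a sulfonyl sulfur: 2-amino-4-chlorophenyl in place of 3-amino-4-bromophenyl on a saturated chain carbon bound to a sulfonyl sulfur.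

Among the measured compounds shown here, three measured steps bear on this. Exchanging one halogen for another did little: bromo in place of fluoro gave a 3.3-fold lower number from compound 1 to compound 3 (0.52 log units; beyond the scatter), a modest step. Changing the whole amino-bearing group mattered far more, with a 100-fold lower number from compound 1 to compound 2 (2.00 log units; beyond the scatter) and a 30-fold higher number from compound 2 to compound 3 (1.48 log units; beyond the scatter), both large. Compound 2 carries 2-amino-4-methoxyphenyl, the measured group closest in name to the entering one. For the measured compounds named here, no measured compound combines that amino placement with a halogen, so the size of the gain remains uncertain.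

A clear move toward compound 2 is therefore expected in this assay, but only part of the way, as an estimated 5.0-fold lower number from compound 3 to compound 4 (0.70 log units; beyond the scatter). The estimate for compound 4 is 150 nM, with an expected range of 35 nM to 700 nM.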

Compound 4, half-maximal inhibitory concentration: 2500 nM
Beside the measured number, compound 4's estimate is 17-fold (1.22 log units) below it; the whole stated range lies below it.
By their numbers in this assay, from the lowest: compound 2; then compound 3; then compounds 1 and 4 (each within the scatter of the next).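

The 2-amino arrangement alone does not bring the low number: in this assay the 2-amino-4-chlorophenyl group gives a 3.3-fold higher number from compound 3 to compound 4 (0.52 log units; beyond the scatter) and, against the 3-amino-4-fluorophenyl group, no change at the digits printed from compound 1 to compound 4 (within the scatter) at this position on a saturated chain carbon bound to a sulfonyl sulfur. Compounds 2 and 4 differ only in one ring substituent, and chloro in place of methoxy gives a 100-fold higher number from compound 2 to compound 4 (2.00 log units; beyond the scatter) so the strong result of compound 2 depends on its methoxy group and not on the amino placement alone. Nothing available gives a measured reason for this dependence on the methoxy group.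

Going by these compounds, it remains open whether an ethoxy or a hydroxyl group could stand in for that methoxy group and keep the low number. The compounds shown also leave open how a 2-amino-4-bromophenyl group would compare with the 2-amino-4-chlorophenyl group.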